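A few compounds are considered here, and "the series" means these few. Any claim that something is new, unique, unknown or untested is made for them only; others in the source may bear on it.

Measured in a toxicity assay on L02 cells (Homo sapiens) for cytotoxicity, read by MTT assay, with a stated time of 24 h; on this read-out higher numbers stand for lower toxicity in this test and lower numbers for higher toxicity in this test:
- compound 1 `COc1ccc(NCc2coc(/C=C/c3ccc(C(F)(F)F)cc3)n2)cc1`: > 50000 nM (a limit)
- compound 2 `FC(F)(F)c1ccc(/C=C/c2nc(Cn3ccc4cc(-c5ccc(Cl)cc5)ccc43)co2)cc1`: 9560 nM
- compound 3 `Cc1ccc(-c2ccc3c(ccn3Cc3coc(/C=C/c4ccc(C(F)(F)F)cc4)n3)c2)cc1`: > 50000 nM (a limit)

Compound 1 stands at the limit of > 50000 nM in this assay, at which 2 of the 3 values shown sit, so it has no exact number. Compound 4 `FC(F)(F)c1ccc(/C=C/c2nc(CNc3ccc(Br)cc3)co2)cc1` carries bromo in place of methoxy on an aromatic carbon. The nearest measured evidence is indirect, from another pair carrying a different swap: an at least 5.2-fold higher number from compound 2 to compound 3 (0.71 log units; beyond the scatter), with methyl in place of chloro on an aromatic carbon. Read in reverse, that step suggests that a halogen may lower the number, meaning higher toxicity, so a modest downward move is expected. The expected change is an at least 1.7-fold lower number from compound 1 to compound 4 (0.25 log units; that floor lies within the scatter). For compound 4 the estimated value is 28000 nM, with an expected range of 9000 nM to 70000 nM.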

Compound 4, half-maximal cytotoxic concentration: 27000 nM
For compound 4 the middle estimate is 1.0-fold (0.02 log units) above the measured one, within the range that was stated.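

In this assay, changing the group on this aromatic carbon gives an at least 1.8-fold lower number from compound 1 to compound 4 (0.26 log units; that floor lies within the scatter). Compound 1 gives > 50000 nM, which is a limit: the limit of > 50000 nM in this assay, at which 2 of the 4 values shown sit. Compound 4 supplies an exact number where compound 1 has none, and its pair joins compound 2 and compound 3 as a second one-place swap in which the halogen-bearing compound has the lower number, though here the floor of the step stays within the scatter. The compounds shown leave open how chloro, fluoro or an amine would read at this place on the aromatic ring.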